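A few compounds are considered here, and "the series" means these few. Any claim that something is new, unique, unknown or untested is made for them only; others in the source may bear on it.

Compound 1 `COc1ccc([C@@H]2CC(=O)c3cc(CC=C(C)C)c(OC)cc3O2)cc1`: 65%
Compound 2 `COc1cc2c(cc1CC=C(C)C)C(=O)C[C@@H](c1ccc(Oc3cccc([N+](=O)[O-])c3)cc1)O2`: 53%
Compound 3 `CCOc1ccc([C@@H]2CC(=O)c3cc(CC=C(C)C)c(OC)cc3O2)cc1`: 57%

These three numbers come from a functional assay on MCF7 cells (Homo sapiens) for inhibition, read by sulforhodamine B assay, with a stated time of 48 h, tested at 50 uM; on this read-out higher numbers stand for more inhibition of growth at the one concentration tested and lower numbers for less inhibition of growth. Compound 3 cannot be told apart from either of the other two, as the steps show: a number 8 percentage points lower from compound 1 to compound 3 (within the scatter) and a number 4 percentage points higher from compound 2 to compound 3 (within the scatter). Among the measured compounds shown here, only one measured step clears the scatter, and it joins the other two compounds: a number 12 percentage points lower from compound 1 to compound 2 (beyond the scatter).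

The next compound to be tested is compound 4 `COc1cc2c(cc1CC=C(C)C)C(=O)C[C@@H](c1ccc(Oc3ccccc3)cc1)O2`. It has phenyl in place of ethyl on an oxygen on an aromatic ring, so ethoxy becomes phenoxy while the rest of the molecule stays the same.

For the measured compounds named here, no measured compound carries a plain phenyl at this spot, so the closest guide is compound 2, which has a 3-nitrophenyl there. Exchanging that ring for the ethyl of compound 3 gave a number 4 percentage points higher from compound 2 to compound 3 (within the scatter), which suggests that ring and ethyl differ little at this oxygen. The modest step of a number 12 percentage points lower from compound 1 to compound 2 (beyond the scatter) shows that a ring in place of methyl can cost some inhibition, so a small drop seems more likely than a rise. The expected change is a number 3 percentage points lower from compound 3 to compound 4 (within the scatter). For compound 4 the estimated value is 54%, within an expected range from 42% to 66%.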

Compound 4, percent growth inhibition at one concentration: 69%
Compound 4: the middle estimate sits 15 percentage points below what was measured, and the stated range ends below it.
By their numbers in this assay, from the lowest: compounds 2, 3, 1 and 4 (each within the scatter of the next, the first and the last beyond it).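

In this assay, among the compounds shown here, phenyl in place of ethyl on this oxygen gives a number 12 percentage points higher from compound 3 to compound 4 (beyond the scatter) and so an aromatic ring at this place does not by itself lower the number, which the earlier compounds had left unclear. Hydrogen in place of nitro on an aromatic carbon gives a number 16 percentage points higher from compound 2 to compound 4 (beyond the scatter) and this ties the lower number of compound 2 to the nitro group rather than to the ring that carries it, while phenyl in place of methyl gives a number 4 percentage points higher from compound 1 to compound 4 (within the scatter) and so these two groups cannot be told apart here even though phenyl holds more carbon. Nothing available explains why these steps fall as they do.

As far as these compounds go, it stays open whether an amine or a carboxylic acid on the phenyl ring would lower the number as nitro does or leave it close to that of compound 4. From the compounds shown here alone, it also stays open whether a longer chain such as butyl on this oxygen would fall nearer to ethyl or to phenyl, and how these compounds would rank at lower concentrations, since all the numbers here come from a single concentration.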